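The source may hold more compounds than are shown below. What is called first, only, known or untested is meant among the compounds shown, and "the series" means these compounds.

Compound 1 `O=C(Cc1csc2nc(-c3ccc(Br)cc3)cn12)N/N=C/c1ccccc1` – 51300 nM
Compound 2 `O=C(Cc1csc2nc(-c3ccc(Br)cc3)cn12)N/N=C/c1ccccc1O` – 42700 nM

Among the measured compounds shown here, in a functional assay on Hs-578T cells (Homo sapiens) for inhibition, read by sulforhodamine B assay, with a stated time of 48 h (a lower number here means a stronger inhibitor of growth, a higher number a weaker inhibitor of growth), compound 2 cannot be told apart from compound 1, the only other measured compound. For the measured compounds named here, the one measured step, a 1.2-fold lower number from compound 1 to compound 2 (0.08 log units; within the scatter), is hydroxy in place of hydrogen on an aromatic carbon. Compound 3 `O=C(Cc1csc2nc(-c3ccc(Br)cc3)cn12)N/N=C/c1ccc(O)cc1` brings (4-hydroxyphenyl in place of 2-hydroxyphenyl on a carbon with a double bond to nitrogen), with 4-hydroxyphenyl in place of 2-hydroxyphenyl on a carbon with a double bond to nitrogen. Going by the values given here, no measured step shows this kind of change, so that small step is only a loose guide, and no shift beyond the scatter is expected. The estimated step is a 1.1-fold higher number from compound 2 to compound 3 (0.02 log units; within the scatter). Compound 3 is expected at 45000 nM, within an estimated range of 21000 nM to 90000 nM.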

Compound 3, concentration for total growth inhibition: 93300 nM
Beside the measured number, compound 3's estimate is 2.1-fold (0.32 log units) below it; measured number above the stated range.
By their numbers in this assay, from the lowest: compounds 2, 1 and 3 (each within the scatter of the next, the first and the last beyond it).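

Only now does the placement of the hydroxy show in this assay: 4-hydroxyphenyl in place of 2-hydroxyphenyl gives a 2.2-fold higher number from compound 2 to compound 3 (0.34 log units; beyond the scatter), a modest step between two groups with the same atoms. Hydroxy in place of hydrogen gives a 1.8-fold higher number from compound 1 to compound 3 (0.26 log units; within the scatter), so each hydroxy compound on its own stays within the scatter of compound 1, and only the two placements separate from each other. Nothing measured here gives a reason for this difference. As far as these compounds go, it remains open whether a methoxy or an amine in place of the hydroxy would follow the same pattern.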